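The source may hold more compounds than are shown below. What is called first, only, known or untested is meant among the compounds shown, and "the series" means these compounds.

The measured compounds and their values:
Compound 1, `CCCS(=O)(=O)Nc1cccc2c1CCCC2c1c[nH]cn1`, gives 1700 nM in an assay on isolated protein for binding affinity to Alpha-1A adrenergic receptor (Rattus norvegicus), read by radioligand binding; a higher number here means a weaker inhibitor, a lower number a stronger inhibitor.
Compound 2, `CC(=O)Nc1cccc2c1CCCC2c1c[nH]cn1`, gives 525 nM.
Compound 3, `CCS(=O)(=O)Nc1cccc(C2CCNC2)c1`, gives 501 nM.

Compound 3 has the lowest of these three numbers. Its value and that of compound 2 lie within the scatter of each other, so the two cannot be placed in order; compound 1 sits at a higher number, beyond the scatter. For the measured compounds named here, the only step between measured compounds that differ in one place is a 3.2-fold lower number from compound 1 to compound 2 (0.51 log units; beyond the scatter), and it concerns the group on the nitrogen, not the ring that changes here.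

Compound 4, `CCS(=O)(=O)Nc1cccc(-c2c[nH]cn2)c1`, has not yet been measured in this assay. It differs from compound 3 in one place: 1H-imidazol-4-yl in place of pyrrolidin-3-yl on an aromatic carbon. Going by the values given here, no measured step covers this exchange. Compounds 1 and 2 both carry the 1H-imidazol-4-yl ring, but on a different core, so their values do not isolate what the ring contributes. With nothing bearing directly on the change, the expectation rests on compound 3 alone. For compound 4 the step of a 1.2-fold higher number from compound 3 to compound 4 (0.08 log units; within the scatter) is expected to stay small, in no firm direction. Compound 4 is estimated at 600 nM, within a range of 150 nM to 2500 nM.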

Compound 4, inhibition constant: < 10000 nM
Compound 4 was reported as a limit; the forecaster's own chance of this, stated with the estimate: 5%; the middle value is on the limit's open side.
By their numbers in this assay, from the lowest: compounds 3 and 2 (each within the scatter of the next); then compound 1.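

Compound 4 gives < 10000 nM in this assay and this is a limit of the assay, not a number. No step from compound 3 to compound 4 can be read, because one side of the comparison is only a limit: the limit of < 10000 nM in this assay, at which 1 of the 4 values shown sits.

In this assay, as far as these compounds go, the effect of 1H-imidazol-4-yl in place of pyrrolidin-3-yl on an aromatic carbon therefore stays open, in both size and direction.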